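A Chlorophenyl in Place of a Chlorothiophenyl

The source may hold more compounds than are shown below. What is called first, only, known or untested is meant among the compounds shown, and "the series" means these compounds.

Compound 1 `O=C(O)CC1COc2cc(OCc3nnc(-c4ccccc4)s3)ccc21`: 3.36%
Compound 2 `O=C(O)CC1COc2cc(OCc3cc(-c4ccccc4)on3)ccc21`: 0.84%
Compound 3 `Cc1nc(-c2ccc(Cl)s2)sc1COc1ccc2c(c1)OCC2CC(=O)O`: 8.34%

Of the compounds shown here, three built on the same acid-bearing core have been measured in a functional assay on CHO cells for agonist activity at Free fatty acid receptor 1 (Homo sapiens), read by FLIPR and calcium flux, tested at 100 nM; a higher number here means a stronger effect of the compound at the concentration tested, a lower number a weaker effect. They differ only in the aromatic group carried at the far end of the ether-linked ring. Compound 3 has the largest of the three numbers, but its gap to compound 1 and its gap to compound 2 both lie within the usual scatter of this assay, so compound 3 cannot be called the most active of the three; all three sit at the low end of the scale.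

Compound 4 `Cc1nc(-c2ccc(Cl)cc2)sc1COc1ccc2c(c1)OCC2CC(=O)O` is the next compound and has not yet been measured in this assay. It differs from compound 3 in one place: 4-chlorophenyl in place of 5-chlorothiophen-2-yl on an aromatic carbon. Among the compounds with values here, no step between two measured compounds is available to calibrate this exchange, and the three measured numbers themselves do not separate from one another. Given that, the expected step from compound 3 to compound 4 is none beyond the scatter, a number 0.3 percentage points lower from compound 3 to compound 4 (within the scatter). Compound 4 is therefore estimated to give 8% in this assay, within a range from 0% to 20%.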

Compound 4, a percentage reported as activity, at one concentration (the size of the read-out at that concentration, not a potency): 53.4%
The estimate for compound 4 lay 45.4 percentage points below the measured number; measured number outside the range, above it.
By their numbers in this assay, from the lowest: compounds 2, 1 and 3 (each within the scatter of the next); then compound 4.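

In this assay, placing 4-chlorophenyl instead of 5-chlorothiophen-2-yl on this aromatic carbon, next to the ring nitrogen and next to the ring sulfur, gives a number 45.1 percentage points higher from compound 3 to compound 4 (beyond the scatter). The three earlier numbers could not be told apart, so this is the only step shown that clearly separates two compounds, and it shows that the read-out can depend strongly on which chlorine-bearing aromatic ring occupies this position, with the methyl group, the ether link and the shared core all unchanged. No measurement shown accounts for the size of this step, so it stands as an observation about this one pair.

From the compounds shown here alone, what remains open is whether the higher number belongs to the six-membered ring of carbon only or depends on the chlorine it carries, a question that a methoxy or a trifluoromethyl group in place of the chlorine would bear on. Going by these compounds, it is also open whether a chlorine on the phenyl ring of compound 1 or compound 2 would raise their numbers in the same way.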